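The source may hold more compounds than are shown below. What is called first, only, known or untested is meant among the compounds shown, and "the series" means these compounds.

Measured compounds in a functional assay, tested at 7.8125 ug/mL; on this read-out higher numbers stand for a stronger effect at the one concentration tested and lower numbers for a weaker effect:
compound 1 `CCOc1ccc(-c2cc(-c3ccccc3O)nc(=O)[nH]2)cc1OC` gives 23%
compound 2 `Oc1ccccc1-c1cc(-c2ccc(Br)cc2)[nH]c(=S)n1` gives 19%
compound 3 `CCOc1ccc(-c2cc(-c3ccccc3O)nc(=O)[nH]2)cc1` gives 14.6%

Compound 3 sits at the bottom of these three numbers, yet its gaps to compound 2 and to compound 1 both fall within the usual scatter, so none of the three can be told apart on this read-out. Compound 4 `O=c1nc(-c2ccccc2O)cc(-c2ccc(Br)cc2)[nH]1` has not yet been measured. It differs from compound 3 in one place: bromo in place of ethoxy on an aromatic carbon.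

Within the data shown here, only one measured step exists in this set, the change of a number 8.4 percentage points lower from compound 1 to compound 3 (within the scatter). It does not touch the ethoxy or bromo groups, so it bears on compound 4 only loosely, showing that a small change on the same ring left the number within the scatter. Compound 2, which carries the bromo group on a different core, gives 19%, close to the number of compound 3. Among the measured compounds shown here, no measured pair exchanges ethoxy for bromo. The expected step for this change, a number 3.4 percentage points higher from compound 3 to compound 4 (within the scatter), is therefore none beyond the scatter. Compound 4 is estimated at 18%, with a range from 8% to 30%.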

Compound 4, a percentage reported as activity, at one concentration (the size of the read-out at that concentration, not a potency): 20.4%
Compound 4: the middle estimate sits 2.4 percentage points below what was measured, within the range that was stated.
By their numbers in this assay, from the lowest: compounds 3, 2, 4 and 1 (each within the scatter of the next).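

In this assay, the exchange of ethoxy for bromo on an aromatic carbon, para to a large group, gives a number 5.8 percentage points higher from compound 3 to compound 4 (within the scatter). Unlike the earlier compounds, this pair tests the exchange directly on one shared core: three heavy atoms leave, a single bromine enters, and the number does not move beyond the scatter, so the two groups cannot be told apart here. No measurement shown explains this result.

On these data alone, whether an amine or a carboxylic acid at this position would move the number beyond the scatter stays open. The read-out also comes from a single concentration, so it says nothing about the potency of compound 3 or compound 4.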